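A few compounds are considered here, and "the series" means these few. Any claim that something is new, unique, unknown or untested is made for them only; others in the source may bear on it.

compound 1 `CC(C)OC(=O)c1cc(N2C(=O)C3=C(CCCC3)C2=O)ccc1Cl` gives 1230 nM
compound 2 `CC(C)(C)OC(=O)c1cc(N2C(=O)C3=C(CCCC3)C2=O)ccc1Cl` gives 81300 nM

Both values come from a functional assay on the whole organism for inhibition, with Scenedesmus acutus as the target; on this read-out higher numbers stand for weaker inhibition and lower numbers for stronger inhibition. Of these two compounds, compound 2 has the higher number, so it is the weaker inhibitor. Next is compound 3 `CCCCCOC(=O)c1cc(N2C(=O)C3=C(CCCC3)C2=O)ccc1Cl`, not yet measured, with pentyl in place of tert-butyl on an oxygen next to a carbonyl group. Among the compounds with values here, one measured step bears on this change: a 66-fold higher number from compound 1 to compound 2 (1.82 log units; beyond the scatter). That large step came with methyl in place of hydrogen on a saturated chain carbon bound to an oxygen, and compound 3 does not carry tert-butyl. A single step is thin evidence for a pentyl chain, yet a return towards compound 1 seems likely. A large step to a lower number is expected, somewhat smaller than the measured one. The expected step is a 20-fold lower number from compound 2 to compound 3 (1.31 log units; beyond the scatter). For compound 3 the estimated value is 4000 nM, with an expected range from 600 nM to 25000 nM.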

Compound 3, half-maximal inhibitory concentration: 4470 nM
For compound 3 the middle estimate is 1.1-fold (0.05 log units) below the measured one, and the stated range covers the measured number.
By their numbers in this assay, from the lowest: compound 1; then compound 3; then compound 2.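

In this assay, pentyl in place of tert-butyl on the oxygen gives an 18-fold lower number from compound 2 to compound 3 (1.26 log units; beyond the scatter) and so recovers most of the earlier loss, which shows that the high number of compound 2 does not extend to every larger alkyl group at this position. The recovery is incomplete, since pentyl in place of isopropyl gives a 3.6-fold higher number from compound 1 to compound 3 (0.56 log units; beyond the scatter) as a modest step, leaving compound 1 with the lowest number of the three. Nothing measured here explains why these groups differ.

As far as these compounds go, whether ethyl or a longer chain such as octyl on this oxygen would give a lower number than compound 1 stays open, so the best chain length is not fixed. Also open, from the compounds shown here alone, is how a carboxylic acid or an amide would compare with these esters.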